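This account rests on a few compounds, and the source may have more. Where it says the series, first, only, none or still open, it means among the compounds named here.

Compound 3 `CN(C)c1c(C#N)c2c(N)ncnc2n1C` gives 4620 nM in an assay on isolated protein for inhibition of Leucine-rich repeat serine/threonine-protein kinase 2 (Homo sapiens), read by TR-FRET and LanthaScreen, with stated times of 50 min and 30 min, in the presence of a further agent that is not named here (a higher number here means a weaker inhibitor, a lower number a stronger inhibitor), the highest of the three numbers recorded. Compound 1 `Cc1c(Nc2nc(N)c3c(C#N)c(N4CCC[C@H]4C)n(C)c3n2)cnn1C` gives 75 nM and compound 2 `C[C@@H]1CCCN1c1c(C#N)c2c(N)nc(Nc3cn[nH]c3)nc2n1C` gives 6 nM; both carry the 2-methylpyrrolidin-1-yl group together with a substituted amino group absent from compound 3. Compound 4 `C[C@@H]1CCCN1c1c(C#N)c2c(N)ncnc2n1C` differs from compound 3 in one place: 2-methylpyrrolidin-1-yl in place of dimethylamino on an aromatic carbon. Among the compounds with values here, the only step measured in one place, a 13-fold lower number from compound 1 to compound 2 (1.10 log units; beyond the scatter), concerns the pyrazole and not this exchange, so no measured step bears on it directly. The gap from compound 3 to compound 1 spans two changes and cannot be split. A modest shift toward a lower number is therefore expected, a 2.3-fold lower number from compound 3 to compound 4 (0.36 log units; beyond the scatter), and compound 4 is estimated at 2000 nM, within 600 nM to 6000 nM.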

Compound 4, half-maximal inhibitory concentration: 15 nM
Estimate against measurement, compound 4: 130-fold (2.12 log units) above, outside the stated range (below it).
By their numbers in this assay, from the lowest: compound 2; then compound 4; then compound 1; then compound 3.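

The exchange on the aromatic carbon next to the ring nitrogen is by itself a large change, a 310-fold lower number from compound 3 to compound 4 (2.49 log units; beyond the scatter), so the 2-methylpyrrolidin-1-yl group needs no substituted amino group to reach a low number. That amino group shifts the number only modestly and in either direction, as a 2.5-fold higher number from compound 2 to compound 4 (0.40 log units; beyond the scatter) and a 5.0-fold lower number from compound 1 to compound 4 (0.70 log units; beyond the scatter) show. No evidence is at hand on what lies behind these steps.

From the compounds shown here alone, whether a plain pyrrolidin-1-yl, a piperidin-1-yl or the opposite configuration at the methyl-bearing carbon would serve here stays open. Dimethylamino appears only with hydrogen on the shared core, so the size of this exchange alongside a (1H-pyrazol-4-yl)amino group is also unknown.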